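The source may report more compounds than this note shows. Statements on the series, on what has been measured and on what is new or still open speak of the compounds shown alone.

Within the data shown here, in a functional assay on Malme-3M cells (Homo sapiens) for inhibition, read by sulforhodamine B assay, with a stated time of 48 h (a higher number here means a weaker inhibitor of growth, a lower number a stronger inhibitor of growth), compound 1 `O=C(Nc1cccc(-n2cc(-c3ccncc3)c(-c3ccc(Cl)c(O)c3)n2)c1)Nc1cccc(C(F)(F)F)c1` gives 20100 nM, the highest of the two numbers measured so far; the nearest compound, compound 2 `O=C(Nc1cccc(-n2cc(-c3ccncc3)c(-c3ccc(Cl)c(O)c3)n2)c1)Nc1cc(C(F)(F)F)cc(C(F)(F)F)c1`, gives 3030 nM. Among the measured compounds shown here, the single measured step, a 6.6-fold lower number from compound 1 to compound 2 (0.82 log units; beyond the scatter), bears on compound 3 `O=C(Nc1cccc(-n2cc(-c3ccncc3)c(-c3ccc(Cl)c(O)c3)n2)c1)Nc1ccc(Cl)c(C(F)(F)F)c1`, where a group likewise enters the same six-membered aromatic ring of carbon only: chloro in place of hydrogen on an aromatic carbon. Because of a 6.6-fold lower number from compound 1 to compound 2 (0.82 log units; beyond the scatter) a modest step downward is expected here as well, though the entering chloro is a different group, so its size is uncertain. For compound 3 the expected value in this assay is 5500 nM, between 1800 nM and 16000 nM, an expected step of a 3.7-fold lower number from compound 1 to compound 3 (0.56 log units; beyond the scatter).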

Compound 3, concentration for total growth inhibition: 1650 nM
Estimate against measurement, compound 3: 3.3-fold (0.52 log units) above; measured number below the stated range.
By their numbers in this assay, from the lowest: compounds 3 and 2 (each within the scatter of the next); then compound 1.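

In this assay, adding a single chloro to the ring that already carries trifluoromethyl, on the carbon ortho to that group and para to a large group, gives a 12-fold lower number from compound 1 to compound 3 (1.09 log units; beyond the scatter). So this position responds strongly to one added chlorine atom, and the earlier step showed this only for an added trifluoromethyl, placed elsewhere on the ring. No measurement shown gives a reason for this step.

On these data alone, it remains open whether the effect is specific to chloro or would also appear with fluoro, bromo, methyl or an amine at this carbon. It is also unknown whether compound 3 would respond in the same way without its trifluoromethyl group.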